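The source may hold more compounds than are shown below. What is called first, only, known or untested is meant among the compounds shown, and "the series" means these compounds.

For the measured compounds named here, in a physicochemical assay for lipophilicity (on this read-out lower numbers stand for lower lipophilicity and higher numbers for higher lipophilicity), compound 1 (`N[C@H]1CC[C@H](Nc2ccc3ncc(-c4cnc(Nc5ccccc5)nc4)n3n2)CC1`) gives 1.6 as the higher of the two numbers so far, and compound 2 (`Cc1ccc(Nc2ncc(-c3cnc4ccc(N[C@H]5CC[C@H](N)CC5)nn34)cn2)nc1`) gives 1.1 as the lower. Compound 3 (`N[C@H]1CC[C@H](Nc2ccc3ncc(-c4cnc(NCc5ccccn5)nc4)n3n2)CC1`) is still unmeasured and carries (pyridin-2-yl)methyl in place of phenyl on a nitrogen on an aromatic ring. Going by the values given here, the one measured step that bears on this is a number 0.50 log units lower from compound 1 to compound 2 (beyond the scatter) with 5-methylpyridin-2-yl in place of phenyl. A drop of similar or smaller size is expected for compound 3 (estimated a number 0.40 log units lower from compound 1 to compound 3 (beyond the scatter)). The estimate for compound 3 is 1.2 (expected range 0.8 to 1.6).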

Compound 3, distribution coefficient: 0.4
Compound 3: the middle estimate sits 0.80 log units above what was measured; the whole stated range lies above it.
By their numbers in this assay, from the lowest: compound 3; then compound 2; then compound 1.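

In this assay (pyridin-2-yl)methyl on a nitrogen on an aromatic ring gives a number 1.20 log units lower from compound 1 to compound 3 (beyond the scatter) and so a larger step than 5-methylpyridin-2-yl gave in this place. Set against 5-methylpyridin-2-yl itself, the change gives a number 0.70 log units lower from compound 2 to compound 3 (beyond the scatter) and shows that the read-out spans more at this position than the first pair revealed. No measurement at hand accounts for the size of these steps.

The compounds shown do not separate the added carbon link from the ring nitrogen. Benzyl on the same nitrogen, or unsubstituted pyridin-2-yl, would separate them.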